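From fluoro to methoxy: a cytotoxicity estimate for compound 3

This account rests on a few compounds, and the source may have more. Where it says the series, first, only, none or still open, it means among the compounds named here.

Measured so far in a functional assay on MM1.S cells (Homo sapiens) for cytotoxicity, read by MTT assay, with a stated time of 48 h (on this read-out higher numbers stand for weaker inhibition and lower numbers for stronger inhibition), for these compounds:
- compound 1 (`FC(F)(F)c1cccc(NN=C2C(Cl)=C(Cl)C(Cl)=C2Cl)c1`) gives 1000 nM
- compound 2 (`Fc1cccc(NN=C2C(Cl)=C(Cl)C(Cl)=C2Cl)c1`) gives 1500 nM

Compound 2 at 1500 nM lies within the usual scatter of compound 1. Compound 3 (`COc1cccc(NN=C2C(Cl)=C(Cl)C(Cl)=C2Cl)c1`) differs from compound 2 by one change (methoxy in place of fluoro on an aromatic carbon), methoxy in place of fluoro on an aromatic carbon. For the measured compounds named here, the one measured step that bears on this (a 1.5-fold higher number from compound 1 to compound 2 (0.18 log units; within the scatter)) also swaps a group on an aromatic carbon, and it stays within the scatter. Going by the values given here, no methoxy compound has been measured yet, so no step beyond the scatter is expected in this assay for this change. The expected step is modest (a 1.1-fold lower number from compound 2 to compound 3 (0.03 log units; within the scatter)). Compound 3 is estimated at 1400 nM with 650 nM to 3000 nM as its expected range.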

Compound 3, half-maximal inhibitory concentration: > 3000 nM
Compound 3 gave a limit, no number; the forecaster's own chance of this, stated with the estimate: 3%; middle value at least 2.1-fold (0.33 log units) from the limit.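

In this assay, the group on this aromatic carbon turns out to matter: swapping trifluoromethyl for methoxy gives an at least 3.0-fold higher number from compound 1 to compound 3 (0.47 log units; beyond the scatter), whereas the earlier swap of trifluoromethyl for fluoro stayed within the scatter. The change from fluoro to methoxy itself gives an at least 2.0-fold higher number from compound 2 to compound 3 (0.30 log units; that floor lies within the scatter), so methoxy is clearly separated only from trifluoromethyl so far. Compound 3 gives > 3000 nM, which is a limit of the assay and not a number: the limit of > 3000 nM in this assay, at which 1 of the 3 values shown sits.

On these data alone, how far compound 3 actually lies past that limit stays open, and so does the true size of both steps. As far as these compounds go, it is also open how an amine or a carboxylic acid on this aromatic carbon would read.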